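The source may report more compounds than this note shows. Statements on the series, on what has been measured and on what is new or still open speak of the compounds shown alone.

Compound 1 `Cc1cccc(-n2nncc2CN2C(=O)C3(C(C#N)=C(N)Oc4c3c3nc5ccccc5nc3c3ccccc43)c3ccccc32)c1`, compound 2 `Cc1ccc(-n2nncc2CN2C(=O)C3(C(C#N)=C(N)Oc4c3c3nc5ccccc5nc3c3ccccc43)c3ccccc32)cc1C` and compound 3 `N#CC1=C(N)Oc2c(N)cc3nc4ccccc4nc3c2C12C(=O)N(Cc1cnnn1-c1cccc(C(F)(F)F)c1)c1ccccc12` share one core and were all tested in an ADME assay on L02 cells (Homo sapiens) for antiproliferative activity, read by MTT assay, with a stated time of 48 h; on this read-out higher numbers stand for weaker inhibition and lower numbers for stronger inhibition. In this assay compound 1 gives > 50000 nM, which is a limit of the assay and not a number. Compound 2 in this assay gives > 50000 nM, again a limit. Among the compounds with values here, compound 3 in this assay gives 38100 nM, the only number among the three results, while the limit of > 50000 nM in this assay, at which 2 of the 3 values shown sit, is where the other two results rest. The step that the two limits leave unreadable from compound 1 to compound 2, a methyl in place of hydrogen on an aromatic carbon, therefore shows nothing about its size.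

Compound 4 `N#CC1=C(N)Oc2c(N)cc3nc4ccccc4nc3c2C12C(=O)N(Cc1cnnn1-c1ccc(Cl)cc1[N+](=O)[O-])c1ccccc12` has not been measured. It differs from compound 3 in one place: 4-chloro-2-nitrophenyl in place of 3-(trifluoromethyl)phenyl on an aromatic nitrogen. Within the data shown here, no measured step touches this kind of change, since compounds 1 and 2 differ from compound 3 in more than one place, and the only measured step is unreadable. There is thus no ground for expecting a shift in either direction beyond the scatter. The step expected in this assay is a 1.0-fold higher number from compound 3 to compound 4 (0.02 log units; within the scatter), close to no change. The estimate for compound 4 in this assay is 40000 nM, within a range from 15000 nM to 100000 nM, with a fair chance that only a limit is reported.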

Compound 4, half-maximal inhibitory concentration: > 50000 nM
Compound 4 gave a limit, no number (the forecaster's own chance of this, stated with the estimate: 45%); middle value at least 1.2-fold (0.09 log units) from the limit.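

In this assay, within the data shown here, the exchange on the aromatic nitrogen gives the first readable step at this position, with 4-chloro-2-nitrophenyl in place of 3-(trifluoromethyl)phenyl: an at least 1.3-fold higher number from compound 3 to compound 4 (0.11 log units; that floor lies within the scatter). Compound 4 gives > 50000 nM, which is a limit of the assay and not a number, so the step has only a floor, and that floor alone does not show a change larger than the usual scatter of repeated measurements. Among these compounds, the change therefore shows no gain in inhibition for compound 4 on these cells, and compound 3 remains the only compound with a number, while the others share one limit: the limit of > 50000 nM in this assay, at which 3 of the 4 values shown sit.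

The compounds shown do not separate the contributions of the chloro and nitro groups, so a plain 4-chlorophenyl or 2-nitrophenyl group at this place could still behave differently from the combined 4-chloro-2-nitrophenyl group. On these data alone, it also remains open whether a phenyl ring carrying an amine or a carboxylic acid on the same aromatic nitrogen would give a number in this assay or another limit.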